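Adding methoxy to compound 3: working notes

A few compounds are considered here, and "the series" means these few. Any claim that something is new, unique, unknown or untested is made for them only; others in the source may bear on it.

In a functional assay with Rattus norvegicus as the target (on this read-out lower numbers stand for an effect already at smaller amounts and higher numbers for an effect only at larger amounts of compound), compound 1 (`CCCCCCCCC(=O)NCc1ccc(O)c(O)c1`) gives 630 nM. Compound 2 (`CCCCCCCCC(=O)NCc1cc(O)cc(OC)c1`) gives > 100000 nM, which is a limit of the assay and not a number. Compound 3 (`CCCCCCCCC(=O)NCc1ccncc1`) gives 28000 nM, the higher of the two actual numbers in this assay. Its nearest neighbour, compound 1, stands at 630 nM, lower by more than the scatter.

The next compound is compound 4 (`CCCCCCCCC(=O)NCc1ccnc(OC)c1`), with this change from compound 3: methoxy in place of hydrogen on an aromatic carbon. It has methoxy in place of hydrogen on an aromatic carbon, next to the ring nitrogen. Within the data shown here, no measured pair isolates this change. Among the measured compounds shown here, the only measured compound with a methoxy group is compound 2, and its > 100000 nM is a limit.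

On that slim basis, a 1.6-fold higher number from compound 3 to compound 4 (0.21 log units; within the scatter) is expected to point toward a higher number in this assay, modest in size and perhaps within the scatter. The estimated value for compound 4 is 45000 nM, with an expected range from 12000 nM to 100000 nM.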

Compound 4, half-maximal effective concentration: 31500 nM
Compound 4: middle estimate off by 1.4-fold (0.15 log units), on the high side, and the stated range covers the measured number.
By their numbers in this assay, from the lowest: compound 1; then compounds 3 and 4 (each within the scatter of the next). At a limit, above all of these: compound 2.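

In this assay, methoxy in place of hydrogen on an aromatic carbon, next to the ring nitrogen, gives a 1.1-fold higher number from compound 3 to compound 4 (0.05 log units; within the scatter). Among these compounds, this is the first reading of a single-place change, and it shows that this position takes methoxy with no shift that can be told from the scatter. Among the compounds shown here, compound 2 stands at a limit and not a number, and it supplies no step to set beside this one: the limit of > 100000 nM in this assay, at which 1 of the 4 values shown sits.

On these data alone, whether an amine or a carboxylic acid at this same position would move the number beyond the scatter remains open, as does the effect of a longer chain. For the compounds shown here, no single-place step yet connects compound 3 or compound 4 to compound 1, so the gap between them remains unassigned to any one change.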